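The compounds below may be only part of what the source reports. "The series", "measured", "known", "first", "only" and "open" are said of these compounds alone.

Measured so far in an ADME assay for permeability, using PAMPA, at pH 7.4; a lower number here means that the compound crosses the layer more slowly, a higher number that the compound crosses the layer faster:

- compound 1, `Cc1nc(-c2ccc(S(C)(=O)=O)c([N+](=O)[O-])c2)sc1C(=O)N1CCC(C)CC1`, gives 912 10^-6 cm/s
- compound 2, `CC1CCN(C(=O)c2sc(-c3ccc(S(C)(=O)=O)c([N+](=O)[O-])c3)nc2C(F)(F)F)CC1`, gives 702 10^-6 cm/s
- compound 3, `Cc1nc(-c2ccc(S(C)(=O)=O)c([N+](=O)[O-])c2)sc1C(=O)N1CC2(C)CC1CC(C)(C)C2`, gives 1420 10^-6 cm/s

Among these three, compound 2 has the lowest number in this assay. Within the data shown here, its nearest neighbour is compound 1, and the only single-point step among the measured compounds is a 1.3-fold lower number from compound 1 to compound 2 (0.11 log units; within the scatter); that change was a trifluoromethyl in place of a methyl on an aromatic carbon, and it stayed within the scatter. Among the measured compounds shown here, compound 3, which carries a different, larger bicyclic amine, sits beyond the scatter above compound 2, but no single-point step links those two.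

The next compound, compound 4, `CS(=O)(=O)c1ccc(-c2nc(C(F)(F)F)c(C(=O)N3CCCCC3)s2)cc1[N+](=O)[O-]`, differs from compound 2 by hydrogen in place of methyl on a saturated ring carbon. For the measured compounds named here, no measured step touches this saturated ring carbon, so nothing here shows directly what removing that methyl does. Going by the values given here, the one measured step, a 1.3-fold lower number from compound 1 to compound 2 (0.11 log units; within the scatter), concerns a different position and was small. On that basis the step of a 1.2-fold lower number from compound 2 to compound 4 (0.07 log units; within the scatter) is expected to stay within the scatter, perhaps drifting slightly downward. Compound 4 is therefore estimated at 600 10^-6 cm/s, with a range from 350 10^-6 cm/s to 1000 10^-6 cm/s.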

Compound 4, apparent permeability: 791 10^-6 cm/s
Compound 4: the middle estimate sits 1.3-fold (0.12 log units) below what was measured, and the stated range covers the measured number.
By their numbers in this assay, from the lowest: compounds 2, 4, 1 and 3 (each within the scatter of the next, the first and the last beyond it).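

In this assay, among these compounds, replacing 4-methylpiperidin-1-yl with piperidin-1-yl gives a 1.1-fold higher number from compound 2 to compound 4 (0.05 log units; within the scatter), the first reading at this saturated ring carbon. Among the compounds shown here, for this pair, then, the methyl three ring bonds from the ring nitrogen can be replaced by hydrogen without the number moving beyond the usual spread of repeat measurements, although this single step covers only one change, made with trifluoromethyl on the aromatic carbon. No measured information is available to explain this result.

The compounds shown leave open what a hydroxyl group, an amine or a longer chain on this same ring carbon would do to the number. They also leave open whether removing this methyl would read the same in compound 1, which carries methyl rather than trifluoromethyl on the aromatic carbon.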